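The source may hold more compounds than are shown below. What is called first, only, known or untested is meant among the compounds shown, and "the series" means these compounds.

Measured so far in an ADME assay on Vero cells (Chlorocebus sabaeus) for cytotoxicity, read by MTT assay, with a stated time of 96 h; on this read-out lower numbers stand for higher toxicity in this test and higher numbers for lower toxicity in this test:

Compound 1 `COc1cc(NCc2ccc(C)o2)ccc1-c1cnco1`: 45200 nM
Compound 2 `COc1cc(/N=C/c2cccs2)ccc1-c1cnco1`: 406000 nM

Compound 1 gives the lower of the two numbers in this assay; compound 2 gives the higher, and the gap between them lies beyond the usual scatter. For the measured compounds named here, no single-point step between these two has been computed.

Compound 3 `COc1cc(NCc2ccc(Cl)s2)ccc1-c1cnco1` is the next one to be measured. It differs from compound 1 in one place: 5-chlorothiophen-2-yl in place of 5-methylfuran-2-yl on a saturated chain carbon bound to a nitrogen on an aromatic ring.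

Given that only compound 1 carries a measured number, the expected step of a 1.3-fold lower number from compound 1 to compound 3 (0.11 log units; within the scatter) is small, most likely none beyond the scatter, with a slight lean toward a lower number. Compound 3 is therefore estimated at 35000 nM, within a range from 12000 nM to 100000 nM.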

Compound 3, half-maximal cytotoxic concentration: 53800 nM
Compound 3: the middle estimate sits 1.5-fold (0.19 log units) below what was measured; low and high end bracket the measured number.
By their numbers in this assay, from the lowest: compounds 1 and 3 (each within the scatter of the next); then compound 2.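

On a saturated chain carbon bound to a nitrogen on an aromatic ring, 5-chlorothiophen-2-yl in place of 5-methylfuran-2-yl gives a 1.2-fold higher number from compound 1 to compound 3 (0.08 log units; within the scatter) in this assay. This position therefore accepts a change of both the ring hetero atom and the ring substituent with no shift beyond the scatter. No measured evidence bears on this result.

The two changes travel together here, so the part each plays stays unresolved. Open too, on these data alone, is whether 5-methylthiophen-2-yl, 5-chlorofuran-2-yl or a plain phenyl ring at this place would hold the number in this assay.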